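The source may report more compounds than this note shows. Statements on the series, on what has been measured and on what is new or still open speak of the compounds shown alone.

Measured compounds:
- compound 1, `CCCOc1ccc2oc(/C=C/[S+](C)[O-])cc(=O)c2c1`, in a functional assay on DLD-1 cells (Homo sapiens) for cytotoxicity, with a stated time of 48 h (on this read-out higher numbers stand for weaker inhibition and lower numbers for stronger inhibition), gives 6200 nM
- compound 2, `CCOc1ccc2oc(/C=C/[S+](C)[O-])cc(=O)c2c1`, gives 4900 nM
- compound 3, `CC(C)COc1ccc2oc(/C=C/[S+](C)[O-])cc(=O)c2c1`, gives 5000 nM

These three share one core and differ only in the alkoxy chain attached to it. The differences between them are small: a 1.3-fold lower number from compound 1 to compound 2 (0.10 log units; within the scatter), a 1.2-fold lower number from compound 1 to compound 3 (0.09 log units; within the scatter) and a 1.0-fold higher number from compound 2 to compound 3 (0.01 log units; within the scatter). Compound 3 stands second highest of the three numbers, but its nearest neighbour is compound 2 and its furthest is compound 1, both within the scatter, so the three cannot be told apart on this read-out.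

Compound 4, `C[S+]([O-])/C=C/c1cc(=O)c2cc(F)ccc2o1`, makes a different kind of change: fluoro in place of isobutoxy on an aromatic carbon. Among the measured compounds shown here, none of the measured steps bears on it, since all of them move only within alkoxy groups of different length, and no pair here swaps an oxygen-bearing group for a single fluorine. The flat behaviour across compounds 1, 2 and 3 gives no direction. The number for compound 4 is therefore estimated to lie near the measured ones, with a wide range, as a step of a 1.4-fold higher number from compound 3 to compound 4 (0.15 log units; within the scatter). Compound 4 is expected at 7000 nM, between 2000 nM and 25000 nM.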

Compound 4, half-maximal inhibitory concentration: 7000 nM
Compound 4: middle estimate and measured number agree at the digits printed; the range from low to high includes it.
By their numbers in this assay, from the lowest: compounds 2, 3, 1 and 4 (each within the scatter of the next).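

In this assay, replacing the alkoxy chain with fluoro on this aromatic carbon gives a 1.4-fold higher number from compound 3 to compound 4 (0.15 log units; within the scatter) for isobutoxy, a 1.4-fold higher number from compound 2 to compound 4 (0.15 log units; within the scatter) for ethoxy and a 1.1-fold higher number from compound 1 to compound 4 (0.05 log units; within the scatter) for propoxy, and all three steps lie within the scatter. The earlier compounds shown here showed only that alkoxy chains of different size read alike here, whereas this result extends that to a much more drastic change: a group of 5 heavy atoms, one of them an oxygen that counts as a hydrogen-bond acceptor, gives way to a single fluorine with no acceptor, and the number still cannot be told apart from the others. For these four compounds, then, the alkoxy oxygen and its chain are not needed to keep the number in this range, though nothing here gives a measured reason for this flat behaviour.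

On these data alone, whether the position stays this indifferent with a free amine, a carboxylic acid or a much longer chain such as decyloxy remains open. Also open, as far as these compounds go, is whether the number would move with a change elsewhere on the molecule, since the rest of the structure is the same in all four compounds.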